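A few compounds are considered here, and "the series" means these few. Any claim that something is new, unique, unknown or untested is made for them only; others in the source may bear on it.

Measured compounds:
compound 1 `O=C(CNc1ccc(F)cc1)Nc1nc2ccc(Cl)cc2s1` — 3.88
compound 2 `S=C(N/N=C/c1ccc(Cl)cc1)Nc1nc2ccc(Cl)cc2s1` — 5.52
compound 3 `S=C(N/N=C/c1ccccc1Cl)Nc1nc2ccc(Cl)cc2s1` — 5.46

In a physicochemical assay for lipophilicity, in phosphate buffer, measured as octanol-water partition (a lower number here means a more polar compound, a higher number a more lipophilic compound), compound 2 gives 5.52, the highest of the three numbers. Compound 3, with the chlorine moved on the benzene ring, gives 5.46, and the step of a number 0.06 log units lower from compound 2 to compound 3 (within the scatter) lies within the scatter. Compound 1 is built differently, with an amide rather than a thiosemicarbazone, and gives 3.88, well below compound 2.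

Compound 4 `O=[N+]([O-])c1ccc(/C=N/NC(=S)Nc2nc3ccc(Cl)cc3s2)cc1` has not yet been measured in this assay. It differs from compound 2 in one place: nitro in place of chloro on an aromatic carbon. For the measured compounds named here, none of the measured steps involves a nitro group, and the only single-change step available, from compound 2 to compound 3, moves a chlorine without exchanging it, so it says little about this swap. The change removes a chlorine and brings in a group with two hydrogen-bond acceptors, which is expected to lower the number. For compound 4 the estimate is 4.5, in a range from 4 to 5.1, which is an expected step of a number 1.02 log units lower from compound 2 to compound 4 (beyond the scatter).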

Compound 4, partition coefficient: 4.68
Estimate against measurement, compound 4: 0.18 log units below; low and high end bracket the measured number.
By their numbers in this assay, from the lowest: compound 1; then compound 4; then compounds 3 and 2 (each within the scatter of the next).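

In this assay, nitro in place of chloro gives a number 0.84 log units lower from compound 2 to compound 4 (beyond the scatter) and so shows that the number can respond to what sits on this aromatic carbon. The earlier change only shifted the chlorine on the benzene ring and gave a number 0.06 log units lower from compound 2 to compound 3 (within the scatter), so it could not show what exchanging the chlorine for another group would do. Nothing measured here explains why this exchange goes with a lower number.

Only one replacement at this place is shown, so it remains open how an amine, a carboxylic acid or a methoxy group would compare with chloro and nitro. Going by these compounds, it is also open whether nitro in place of the chlorine of compound 3 would give a step of similar size.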